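Piperazine cap variation on the shared core

This account rests on a few compounds, and the source may have more. Where it says the series, first, only, none or still open, it means among the compounds named here.

Measured so far:
compound 1 `CN(C[C@H]1Cc2c(cccc2N2CCN(C3COC3)CC2)CN1)[C@H]1CCCc2cccnc21` gives 381 nM
compound 2 `Cc1cnc(CN(C)C[C@H]2Cc3c(cccc3N3CCNCC3)CN2)c(C)c1` gives 21.4 nM

In a functional assay on CCRF-CEM cells for antagonist activity at C-X-C chemokine receptor type 4 (Homo sapiens), read by calcium flux, with stated times of 25 min and 90 s (on this read-out lower numbers stand for stronger inhibition and higher numbers for weaker inhibition), compound 1 stands at the higher of the two numbers, with 381 nM. Compound 2 gives 21.4 nM in this assay, a gap well beyond the scatter, but the two structures differ in more than one place, so no single change can be held to account for it.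

Compound 3 `C[C@@H]1CN(c2cccc3c2C[C@H](CN(C)[C@H]2CCCc4cccnc42)NC3)C[C@H](C)N1C` is not yet measured. It differs from compound 1 in one place: 3,4,5-trimethylpiperazin-1-yl in place of 4-(oxetan-3-yl)piperazin-1-yl on an aromatic carbon. For the measured compounds named here, no step between measured compounds isolates this change. Compound 2, which carries a piperazine free of the 4-(oxetan-3-yl) group, gives the lower number, whereas compound 3 is methylated on the corresponding ring nitrogen, so the support for a gain is weak. For compound 3 the expected step from compound 1 is a 1.5-fold lower number from compound 1 to compound 3 (0.18 log units; within the scatter), a small move towards lower numbers, not clearly beyond the scatter. The estimate for compound 3 in this assay is 250 nM, with a range of 80 nM to 900 nM.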

Compound 3, half-maximal inhibitory concentration: 14.1 nM
Beside the measured number, compound 3's estimate is 18-fold (1.25 log units) above it; measured number below the stated range.
By their numbers in this assay, from the lowest: compounds 3 and 2 (each within the scatter of the next); then compound 1.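

At this aromatic carbon the cap on the piperazine matters: 3,4,5-trimethylpiperazin-1-yl in place of 4-(oxetan-3-yl)piperazin-1-yl gives a 27-fold lower number from compound 1 to compound 3 (1.43 log units; beyond the scatter) in this assay on the shared core. For the compounds shown here, this is the first step that isolates a change in one place, and it lies beyond the scatter, so this position responds strongly to the choice of cap. Nothing measured here bears on the reason for this step.

The step exchanges the whole cap, so the compounds shown do not separate the loss of the oxetan-3-yl group from the gain of the methyl groups and the defined stereocentres. Also open, from the compounds shown here alone, is how 4-methylpiperazin-1-yl, which keeps only the methyl group on the ring nitrogen, or a morpholine would read at this position.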